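A few compounds are considered here, and "the series" means these few. Any claim that something is new, unique, unknown or untested is made for them only; others in the source may bear on it.

Working notes on the cinnamate ester series, growth-inhibition set.

Three compounds stand measured in a functional assay on the whole organism for inhibition, with Brassica rapa subsp. chinensis as the target, with a stated time of 3 days, tested at 100 ppm; a lower number here means less inhibition of growth, a higher number more inhibition of growth at the concentration tested. Compound 2 `CC(C)OC(=O)/C=C/c1ccccc1` gives 2%, the lowest of the three numbers. Compound 1 `CCCOC(=O)/C=C/c1ccc(C(C)C)cc1` gives 8%, a number within the scatter of compound 2, so no order between these two can be read. Compound 3 `CCC(C)OC(=O)/C=C/c1ccccc1` gives 18%; the step of a number 16 percentage points higher from compound 2 to compound 3 (beyond the scatter) is the only one in the set that lies beyond the scatter, and it comes from a change on the ester chain, not on the ring.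

Compound 4 `CC(C)OC(=O)/C=C/c1ccc(C(C)C)cc1` is the next to be measured. Relative to compound 2 the change is isopropyl in place of hydrogen on an aromatic carbon. For the measured compounds named here, no measured single-point step covers this change: compound 1 carries the same isopropyl on the ring, but its ester chain differs from that of compound 2, so compound 1 and compound 2 are not a one-place pair. What compound 1 and compound 2 show is two numbers within the scatter of each other, which gives no sign that the ring substituent moves the read-out much.

For compound 4 the expected step from compound 2 is a number 6 percentage points higher from compound 2 to compound 4 (within the scatter), no change beyond the scatter. Compound 4 is therefore estimated at 8%, in the range 0% to 25%.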

Compound 4, percent growth inhibition at one concentration: 18%
Compound 4: middle estimate off by 10 percentage points, on the low side; the range from low to high includes it.
By their numbers in this assay, from the lowest: compounds 2, 1, 3 and 4 (each within the scatter of the next, the first and the last beyond it).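

For the compounds shown here, for the first time the series has a one-place reading on the ring: in this assay, isopropyl in place of hydrogen on an aromatic carbon, para to a group of 8 heavy atoms, gives a number 16 percentage points higher from compound 2 to compound 4 (beyond the scatter) and so shows that a change at this position can move the read-out beyond the scatter, a modest step of the same printed size as the one on the ester chain. With the ring isopropyl held in place, isopropyl in place of propyl on an oxygen next to a carbonyl group gives a number 10 percentage points higher from compound 1 to compound 4 (within the scatter) and leaves no order between these two esters to be read. Nothing at hand bears on the origin of the ring step.

Open, from the compounds shown here alone, is whether this step belongs to isopropyl in particular or would also appear with a smaller or different group at the same position, such as methyl, methoxy or chlorine. Also open, going by these compounds, is whether the ring step holds on other ester chains, such as the chain of compound 3 or a longer chain such as hexyl, since it rests on a single pair at one concentration.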